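The compounds below may be only part of what the source reports. "The series", "measured", "known", "first", "only" and "open" are said of these compounds alone.

Measured so far:
compound 1, `C=C(Br)C(=O)Nc1cccc(-c2cn3c(-c4ccc(OC)cc4)csc3n2)c1`: 620 nM
compound 2, `Nc1cccc(-c2cn3nc(-c4ccc(F)cc4)sc3n2)c1`: 33000 nM
compound 3, `C=C(Br)C(=O)Nc1cccc(-c2cn3nc(Cc4ccc(OC)cc4)sc3n2)c1`: 850 nM

In a functional assay on FM3A cells (Mus musculus) for inhibition, read by cell counting, with a stated time of 2 days (a higher number here means a weaker inhibitor, a lower number a stronger inhibitor), compound 3 stands second highest of the three numbers. Its nearest neighbour is compound 1, whose 620 nM lies within the scatter of the value of compound 3, so no order between the two can be read. The furthest is compound 2, which with 33000 nM sits far beyond the scatter and is the only one of the three without the bromoacrylamide.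

Compound 4, `C=C(Br)C(=O)Nc1cccc(-c2cn3nc(Cc4ccccc4)sc3n2)c1`, differs from compound 3 in one place: hydrogen in place of methoxy on an aromatic carbon. For the measured compounds named here, no pair of measured compounds isolates this change, so its size is not known from the series. The methoxy is a small group at the outer edge of the molecule, and the shared core and the bromoacrylamide stay untouched. The step expected in this assay from compound 3 to compound 4 is therefore a modest one, if any, toward a slightly higher number, estimated as a 1.3-fold higher number from compound 3 to compound 4 (0.11 log units; within the scatter). Compound 4 is expected to give 1100 nM, with a range of 400 nM to 3000 nM.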

Compound 4, half-maximal inhibitory concentration: 3000 nM
Compound 4: the middle estimate sits 2.7-fold (0.44 log units) below what was measured; low and high end bracket the measured number.
By their numbers in this assay, from the lowest: compounds 1 and 3 (each within the scatter of the next); then compound 4; then compound 2.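

In this assay, hydrogen in place of methoxy, which turns 4-methoxybenzyl into benzyl, gives a 3.5-fold higher number from compound 3 to compound 4 (0.55 log units; beyond the scatter). For the compounds shown here, this is the only step that isolates a single change, and it shows that, with the shared core and the bromoacrylamide held fixed, the methoxy on this aromatic carbon, para to a large group, makes a difference beyond the scatter. Nothing among the data shown accounts for the size of this step.

Open, going by these compounds, is whether the methoxy is specifically required at this place, or whether a hydroxy, a fluorine, an amine or a longer ether such as ethoxy would serve equally. Also open, on these data alone, is whether the same change would give a similar step on the 4-methoxyphenyl group of compound 1.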